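A few compounds are considered here, and "the series" means these few. Any claim that something is new, unique, unknown or untested is made for them only; others in the source may bear on it.

Measured in a functional assay on ECa-109 cells for inhibition, with ECa-109 cell line (Homo sapiens) as the target, read by sulforhodamine B assay; on this read-out lower numbers stand for stronger inhibition and higher numbers for weaker inhibition:

Compound 1 `CCCc1ccc(NC2=CC(=O)c3c(nc4n3[C@H]3OC[C@@H](O)[C@H]3OC4)C2=O)cc1` gives > 4000 nM, a limit of the assay.
Compound 2 `COc1ccc(NC2=CC(=O)c3c(nc4n3[C@H]3OC[C@@H](O)[C@H]3OC4)C2=O)cc1` gives 3410 nM.
Compound 3 `O=C1C=C(NCc2ccccc2)C(=O)c2c1nc1n2[C@H]2OC[C@@H](O)[C@H]2OC1` gives > 8000 nM, a limit of the assay.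

Compound 3 thus stands at a limit, not at a number, as the limit of > 8000 nM in this assay, at which 1 of the 3 values shown sits, records; compound 1 also stands at a limit, (the limit of > 4000 nM in this assay, at which 1 of the 3 values shown sits). Within the data shown here, the one measured step, an at least 1.1-fold lower number from compound 1 to compound 2 (0.06 log units; that floor lies within the scatter), lies within the scatter and concerns a substituent on an aromatic carbon, not the group on the amine nitrogen. Compound 4 `CCOc1ccccc1NC1=CC(=O)c2nc3n(c2C1=O)[C@H]1OC[C@@H](O)[C@H]1OC3` is not yet measured and differs from compound 3 by 2-ethoxyphenyl in place of benzyl on an amine nitrogen. Among the measured compounds shown here, no measured step covers this change; compound 1 and compound 2, which carry an aryl group on that nitrogen, show one number and one limit. Compound 4 is therefore expected near 3500 nM, between 1200 nM and 10000 nM. For compound 4 this means an expected step of an at least 2.2-fold lower number from compound 3 to compound 4 (0.35 log units; beyond the scatter).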

Compound 4, half-maximal inhibitory concentration: 4630 nM
Estimate against measurement, compound 4: 1.3-fold (0.12 log units) below; the range from low to high includes it.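

At the amine nitrogen, 2-ethoxyphenyl in place of benzyl yields a measured number where benzyl yielded only a limit, giving an at least 1.7-fold lower number from compound 3 to compound 4 (0.23 log units; that floor lies within the scatter). Among these compounds, this is the only measured step at this nitrogen, and it cannot be sized beyond that floor. The floor stands as it does because compound 3 sits at a limit of the assay: the limit of > 8000 nM in this assay, at which 1 of the 4 values shown sits.

The compounds shown leave open how large this step really is. They also leave open whether an amine or a carboxylic acid on the aromatic ring, or a longer chain in place of ethoxy, would shift the number.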